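The source may report more compounds than this note shows. Statements on the series, on what has been measured and on what is new or still open speak of the compounds shown alone.

Measured in a functional assay on G-361 cells (Homo sapiens) for antiproliferative activity, with a stated time of 72 h; on this read-out lower numbers stand for stronger inhibition and higher numbers for weaker inhibition:

- Compound 1 `OC[C@H]1O[C@@H](n2cnc3c(NCc4ccc(Br)cc4)ncnc32)[C@H](O)[C@@H]1O`: > 166000 nM
- Compound 2 `COc1ccccc1CNc1ncnc2c1ncn2[C@@H]1O[C@H](CO)[C@@H](O)[C@H]1O`: > 166000 nM
- Compound 3 `COc1cccc(CNc2ncnc3c2ncn3[C@@H]2O[C@H](CO)[C@@H](O)[C@H]2O)c1`: "not determined" (no result reported)

The value of compound 1 is a limit of the assay, not a number. The value of compound 2 is also a limit. Going by the values given here, compound 3 gives "not determined" (no result reported), so it has no place on the scale, and the only values around it are the limit of > 166000 nM in this assay, at which 2 of the 3 values shown sit.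

Compound 4 `OC[C@H]1O[C@@H](n2cnc3c(NCc4ccc(Cl)c(Cl)c4)ncnc32)[C@H](O)[C@@H]1O` differs from compound 3 as follows: 3,4-dichlorophenyl in place of 3-methoxyphenyl on a saturated chain carbon bound to a nitrogen on an aromatic ring. Among the compounds with values here, the one measured step that bears on this change is a step that the two limits leave unreadable from compound 1 to compound 2, made at the same place. No size or direction of step can therefore be expected in this assay. Weak inhibition is still the expectation, because of the limit of > 166000 nM in this assay, at which 2 of the 3 values shown sit. The estimated value for compound 4 is 150000 nM, with an expected range from 40000 nM to 166000 nM.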

Compound 4, half-maximal inhibitory concentration: 145000 nM
Compound 4: middle estimate off by 1.0-fold (0.01 log units), on the high side, and the stated range covers the measured number.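

With 3,4-dichlorophenyl at this position, this assay yields a measured number rather than a limit: compound 4 gives 145000 nM. Set against the limits of the two earlier compounds, this is an at least 1.1-fold lower number from compound 2 to compound 4 (0.05 log units; that floor lies within the scatter) and an at least 1.1-fold lower number from compound 1 to compound 4 (0.05 log units; that floor lies within the scatter). Neither floor demonstrates a real gain, and inhibition remains weak across this series: the limit of > 166000 nM in this assay, at which 2 of the 4 values shown sit.

Still open, as far as these compounds go, is whether an amine or a carboxylic acid on the phenyl ring would lower the number. The same question stands for a longer chain between that ring and the nitrogen.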